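Taking the ethoxy group off compound 3

A few compounds are considered here, and "the series" means these few. Any claim that something is new, unique, unknown or untested is made for them only; others in the source may bear on it.

Values in a functional assay on ECa-109 cells for inhibition, with ECa-109 cell line (Homo sapiens) as the target, read by sulforhodamine B assay; a lower number here means a stronger inhibitor, a higher number a weaker inhibitor:
Compound 1 `CCCc1ccc(NC2=CC(=O)c3nc4n(c3C2=O)[C@H]2OC[C@@H](O)[C@H]2OC4)cc1`: > 4000 nM
Compound 2 `COc1ccccc1NC1=CC(=O)c2nc3n(c2C1=O)[C@H]1OC[C@@H](O)[C@H]1OC3`: > 4000 nM
Compound 3 `CCOc1ccc(NC2=CC(=O)c3nc4n(c3C2=O)[C@H]2OC[C@@H](O)[C@H]2OC4)cc1`: 3210 nM

For the measured compounds named here, compound 3 carries the only true number of the three. The entry for compound 1 is a limit. The entry for compound 2 is also a limit.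

Compound 4 `O=C1C=C(Nc2ccccc2)C(=O)c2c1nc1n2[C@H]2OC[C@@H](O)[C@H]2OC1` differs from compound 3 as follows: hydrogen in place of ethoxy on an aromatic carbon. Hydrogen stands in place of ethoxy on an aromatic carbon, para to a large group, so 4-ethoxyphenyl becomes phenyl.

Going by the values given here, no measured step removes the group outright. The nearest is an at least 1.2-fold lower number from compound 1 to compound 3 (0.09 log units; that floor lies within the scatter), with ethoxy in place of propyl. Next is an at least 1.2-fold lower number from compound 2 to compound 3 (0.09 log units; that floor lies within the scatter), with 4-ethoxyphenyl in place of 2-methoxyphenyl. The step that the two limits leave unreadable from compound 1 to compound 2 gives no size. With only these floors to go on, a small move to a higher number in this assay is expected, possibly none beyond the scatter. The expected step is a 1.4-fold higher number from compound 3 to compound 4 (0.15 log units; within the scatter). For compound 4 the estimated value is 4500 nM, with an expected range from 2000 nM to 10000 nM.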

Compound 4, half-maximal inhibitory concentration: 4970 nM
Beside the measured number, compound 4's estimate is 1.1-fold (0.04 log units) below it, and the stated range covers the measured number.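

In this assay, for the compounds shown here, removing the ethoxy group gives the first step at this position with a true number at both ends: a 1.5-fold higher number from compound 3 to compound 4 (0.19 log units; within the scatter). The phenyl compound and the 4-ethoxyphenyl compound therefore cannot be told apart in this read-out, and the ethoxy group, on an aromatic carbon para to a large group, is not shown to matter here. The steps from compound 1 and from compound 2 to compound 4 cannot be read, as the values of compound 1 and compound 2 stand only as a limit: the limit of > 4000 nM in this assay, at which 2 of the 4 values shown sit.

The compounds shown leave open whether an amine or a carboxylic acid in place of the ethoxy group would move the number beyond the scatter. They also leave open whether any change to the shared core would do so.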